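The compounds below may be only part of what the source reports. "The series", "measured", "known", "first", "only" and "open" are said of these compounds alone.

Measured in a functional assay on ASPC1 cells (Homo sapiens) for inhibition, read by MTT assay, with a stated time of 72 h; a higher number here means a weaker inhibitor of growth, a lower number a stronger inhibitor of growth:
compound 1 `COc1ccc(CNCCCNS(=O)(=O)c2cc(C(F)(F)F)cc(C(F)(F)F)c2)cc1OC`: 6400 nM
compound 2 `O=S(=O)(NCCCNCc1ccc(Cl)c(C(F)(F)F)c1)c1cc(C(F)(F)F)cc(C(F)(F)F)c1`: 9600 nM
compound 3 `O=S(=O)(NCCCNCc1ccc(Br)cc1)c1cc(C(F)(F)F)cc(C(F)(F)F)c1`: 2800 nM

Compound 3 gives the lowest number of the three. The steps leading to it are a 2.3-fold lower number from compound 1 to compound 3 (0.36 log units; beyond the scatter) and a 3.4-fold lower number from compound 2 to compound 3 (0.54 log units; beyond the scatter), both beyond the scatter, so compound 3 stands clear of the other two. Between the other two the step is a 1.5-fold higher number from compound 1 to compound 2 (0.18 log units; within the scatter), which is within the scatter.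

Compound 4 `O=S(=O)(NCCCNCc1cccc2ccccc12)c1cc(C(F)(F)F)cc(C(F)(F)F)c1` is not yet measured. It differs from compound 3 by naphthalen-1-yl in place of 4-bromophenyl on a saturated chain carbon bound to an amine nitrogen. All three measured steps change the aryl group on this same saturated chain carbon bound to the amine nitrogen, and each of them is modest or within the scatter. Within the data shown here, none of them replaces a single six-membered aromatic ring with a group of two six-membered aromatic rings, so no measured step bears directly on this change. What the measured steps do show is that exchanging the aryl group at this position moves the number in this assay by a modest amount only, in either direction. For compound 4 a step of a 1.3-fold higher number from compound 3 to compound 4 (0.10 log units; within the scatter) is therefore expected, with the direction uncertain and a slight lean back toward the middle of the measured range. Compound 4 is estimated at 3500 nM, with a range of 1400 nM to 9000 nM.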

Compound 4, concentration for 50% growth inhibition: 21000 nM
For compound 4 the middle estimate is 6.0-fold (0.78 log units) below the measured one; the whole stated range lies below it.
By their numbers in this assay, from the lowest: compound 3; then compounds 1 and 2 (each within the scatter of the next); then compound 4.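

In this assay the change to naphthalen-1-yl on a saturated chain carbon bound to an amine nitrogen gives the largest step in the series, with a 7.5-fold higher number from compound 3 to compound 4 (0.88 log units; beyond the scatter) and with the number also rising in a 2.2-fold higher number from compound 2 to compound 4 (0.34 log units; beyond the scatter) and in a 3.3-fold higher number from compound 1 to compound 4 (0.52 log units; beyond the scatter) so that compound 4 is the weakest inhibitor of growth of the four. Among these compounds, this position therefore does not tolerate every aryl exchange with only a small shift: the one group with 2 six-membered aromatic rings gives the highest number, although one compound cannot separate the effect of the second ring from the loss of the bromine. Nothing shown gives a reason for this rise.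

The compounds shown leave open whether the higher number belongs to the second ring itself or to the way it is attached, a question that naphthalen-2-yl on the same carbon would address, and whether phenyl or 4-fluorophenyl would stay near compound 3. Also open, going by these compounds, is whether the same order of aryl groups would hold with a longer chain in the shared core.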